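Side-chain variation on the shared core: cytotoxicity notes

The source may report more compounds than this note shows. Statements on the series, on what has been measured and on what is new or still open speak of the compounds shown alone.

Compound 1 `O=C1CCC(=O)N1C[C@H]1CN(c2ccc(-n3cc(-c4ccccn4)cn3)c(F)c2)C(=O)O1` and compound 2 `COC[C@H]1CN(c2ccc(-n3cc(-c4ccccn4)cn3)c(F)c2)C(=O)O1` share one core and differ only in the group on the saturated chain carbon bound to a saturated ring carbon. In an ADME assay on L02 cells (Homo sapiens) for cytotoxicity, read by MTT assay, with a stated time of 48 h (a higher number here means a weaker inhibitor, a lower number a stronger inhibitor), compound 1 gives > 400 ug/mL, which is a limit of the assay and not a number. In this assay compound 2 likewise gives > 400 ug/mL, again a limit rather than a number. The step that the two limits leave unreadable from compound 1 to compound 2 therefore cannot be read from the two values. Compound 2 thus stands at the limit of this assay, as does every value obtained so far in the series: the limit of > 400 ug/mL in this assay, at which 2 of the 2 values shown sit.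

Compound 3 `O=C1O[C@@H](CSc2cccs2)CN1c1ccc(-n2cc(-c3ccccn3)cn2)c(F)c1` carries the change ((thiophen-2-yl)sulfanyl in place of methoxy on a saturated chain carbon bound to a saturated ring carbon). Among the compounds with values here, the only measured step bears on this change merely in that both of its ends sit at the limit; its size is not readable, so it gives no direction. The expectation for compound 3 in this assay is therefore a value at or near the same limit, estimated as 400 ug/mL with a range from 150 ug/mL to 900 ug/mL. The step of a number no higher from compound 2 to compound 3 (the limit leaves the size open) expected from this is no step beyond the scatter.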

Compound 3, half-maximal inhibitory concentration: > 400 ug/mL
Compound 3 ended at the assay's limit (the forecaster's own chance of this, stated with the estimate: 70%); the middle value lies on the limit itself.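

Within the data shown here, no step among compound 1, compound 2 and compound 3 can be read, as all three values are limits of the assay and not numbers: the limit of > 400 ug/mL in this assay, at which 3 of the 3 values shown sit. The compounds shown leave open how these three side chains compare in this assay, and whether any group at this place on the shared core gives a value short of the limit.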